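Swapping a methoxymethyl for a fluoromethyl on the chain

The source may report more compounds than this note shows. Statements on the series, on what has been measured and on what is new or still open speak of the compounds shown alone.

Compound 1 `COC[C@@H](C)[C@H](C)C(c1ccc(O)c(OC)c1)c1ccc(O)c(OC)c1` gives 58000 nM in a functional assay on HeLa cells (Homo sapiens) for cytotoxicity, read by WST assay, with a stated time of 48 h (a higher number here means a weaker inhibitor, a lower number a stronger inhibitor), the higher of the two numbers measured there. Compound 3 `COc1cc(C(c2ccc(O)c(OC)c2)[C@H](CF)C(C)C)ccc1O` gives 19000 nM in this assay. Compound 2 `COc1cc(C(c2ccc(O)c(OC)c2)[C@H](C)[C@@H](C)CO)ccc1O` reaches only a limit in this assay, > 100000 nM, which is not a number; this is the limit of > 100000 nM in this assay, at which 1 of the 3 values shown sits.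

Compound 4 `COc1cc(C(c2ccc(O)c(OC)c2)[C@@H](C)[C@@H](C)CF)ccc1O` is not yet measured. It differs from compound 1 in one place: 1-(fluoromethyl)ethyl in place of 1-(methoxymethyl)ethyl on a saturated chain carbon bound to two saturated chain carbons. Among the measured compounds shown here, two measured steps bear on this change. First, a 3.1-fold lower number from compound 1 to compound 3 (0.48 log units; beyond the scatter), where a fluoromethyl also enters in place of a methoxymethyl, though the rest of the chain is rearranged as well. Second, an at least 1.7-fold higher number from compound 1 to compound 2 (0.23 log units; that floor lies within the scatter), where a hydroxymethyl enters instead; and between those two, an at least 5.2-fold lower number from compound 2 to compound 3 (0.72 log units; beyond the scatter). The fluoromethyl step is the closer precedent, so a modest drop is expected rather than none. For compound 4 the expected step is a 1.9-fold lower number from compound 1 to compound 4 (0.29 log units; within the scatter). Compound 4 is therefore estimated at 30000 nM, with a range from 12000 nM to 80000 nM.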

Compound 4, half-maximal inhibitory concentration: 42000 nM
Compound 4: middle estimate off by 1.4-fold (0.15 log units), on the low side; the measured number falls inside the stated range.
By their numbers in this assay, from the lowest: compound 3; then compounds 4 and 1 (each within the scatter of the next). At a limit, above all of these: compound 2.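

With the chain of compound 1 kept, fluoromethyl in place of methoxymethyl gives no readable change in this assay, with a 1.4-fold lower number from compound 1 to compound 4 (0.14 log units; within the scatter) lying within the scatter, so the earlier drop is not reproduced by this swap alone, and the arrangement of the chain also counts, with a 2.2-fold higher number from compound 3 to compound 4 (0.34 log units; beyond the scatter) on going from 1-(fluoromethyl)-2-methylpropyl to 2-(fluoromethyl)-1-methylpropyl. On the same chain, fluoromethyl also compares favourably with hydroxymethyl, with an at least 2.3-fold lower number from compound 2 to compound 4 (0.37 log units; beyond the scatter) as a clear step. That step is only a floor, as the entry for compound 2 is a limit and not a number: the limit of > 100000 nM in this assay, at which 1 of the 4 values shown sits.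

The compounds shown leave open how an amine or a carboxylic acid at the end of this chain would behave, or a longer chain. They also leave open whether the chain arrangement of compound 3 would give a similar number with methoxymethyl in place of fluoromethyl.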